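From pyridin-2-yl to oxan-2-yl on a shared core

The source may report more compounds than this note shows. Statements on the series, on what has been measured and on what is new or still open speak of the compounds shown alone.

In a physicochemical assay for solubility (a lower number here means a less soluble compound, a higher number a more soluble compound), compound 1 `C[C@H](Oc1ccc(S(C)(=O)=O)cc1C(=O)N1Cc2ccccc2C1)C(F)(F)F` reaches only a limit of the assay, < 1 ug/mL. Compound 2 `C[C@H](Oc1ccc(S(C)(=O)=O)cc1C(=O)N1Cc2ccc(N3CCN(C)CC3)cc2C1)C(F)(F)F` gives 490 ug/mL. Compound 3 `C[C@H](Oc1ccc(S(C)(=O)=O)cc1C(=O)N1Cc2ccc(-c3ccccn3)cc2C1)C(F)(F)F` gives 30 ug/mL, the lower of the two actual numbers, and the gap is a 16-fold lower number from compound 2 to compound 3 (1.21 log units; beyond the scatter).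

Compound 4 `C[C@H](Oc1ccc(S(C)(=O)=O)cc1C(=O)N1Cc2ccc(C3CCCCO3)cc2C1)C(F)(F)F` carries oxan-2-yl in place of pyridin-2-yl on an aromatic carbon. Going by the values given here, no measured step makes this exchange directly. Three large steps concern the same carbon: an at least 490-fold higher number from compound 1 to compound 2 (2.69 log units; beyond the scatter), an at least 30-fold higher number from compound 1 to compound 3 (1.47 log units; beyond the scatter) and the gap already given. The second of these came with a six-membered ring, and the entering group is also a six-membered ring with no net charge, so most of that gain is expected to remain. The loss of aromaticity adds uncertainty, and the direction is only tentatively expected to be downward, with little change beyond the scatter. The expected step is a 1.9-fold lower number from compound 3 to compound 4 (0.27 log units; within the scatter). For compound 4 the estimated solubility is 16 ug/mL, with an expected range of 4 ug/mL to 60 ug/mL.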

Compound 4, solubility: < 1 ug/mL
Compound 4 was reported as a limit (the forecaster's own chance of this, stated with the estimate: 7%); at least 16-fold (1.20 log units) between middle value and limit.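

In this assay, exchanging one six-membered ring for another on this aromatic carbon gives an at least 30-fold lower number from compound 3 to compound 4 (1.47 log units; beyond the scatter), while the exchange of 4-methylpiperazin-1-yl for oxan-2-yl gives an at least 490-fold lower number from compound 2 to compound 4 (2.69 log units; beyond the scatter). Pyridin-2-yl and oxan-2-yl have the same counts of heavy atoms, hydrogen-bond donors and acceptors and the same lack of net charge, so those counts alone do not set the number at this position. Compound 4 stands at a limit of the assay, as does compound 1, so the step between those two cannot be read: the limit of < 1 ug/mL in this assay, at which 2 of the 4 values shown sit.

The compounds shown leave open whether the number of compound 3 goes with the aromatic ring or with its nitrogen, a distinction that a phenyl or a piperidin-2-yl group on the same carbon could address. Going by these compounds, how an open-chain amine would compare with 4-methylpiperazin-1-yl also remains open.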